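The source may report more compounds than this note shows. Statements on the series, on what has been measured and on what is new or still open speak of the compounds shown alone.

Among the compounds with values here, the three compounds measured so far share one core. Compound 1 `O=C(CSC(=S)N[C@H]1CCOC1=O)Nc1ccc(Cl)cc1` was tested in a functional assay on SMMC-7721 cells (Homo sapiens) for cytotoxicity, read by MTT assay, with a stated time of 72 h; a higher number here means a weaker inhibitor, a lower number a stronger inhibitor; compound 1 gives > 128000 nM, which is a limit of the assay rather than a number. Compound 2 `O=C(CSC(=S)N[C@H]1CCOC1=O)Nc1ccccc1` likewise gives only a limit, > 128000 nM. Compound 3 `CC(=O)c1ccc(NC(=O)CSC(=S)N[C@H]2CCOC2=O)cc1` also gives a limit, > 128000 nM, so compound 3 stands at the same limit as the other two and has no number of its own. The steps between them, a step that the two limits leave unreadable from compound 1 to compound 2, a step that the two limits leave unreadable from compound 1 to compound 3 and a step that the two limits leave unreadable from compound 2 to compound 3, cannot be read because of the limit of > 128000 nM in this assay, at which 3 of the 3 values shown sit.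

Compound 4 `O=C(CSC(=S)N[C@H]1CCOC1=O)Nc1ccc(C(=O)/C=C/c2ccc(Br)cc2)cc1` is the next compound. It differs from compound 3 by 2-(4-bromophenyl)ethenyl in place of methyl on a carbonyl carbon. Within the data shown here, none of the measured steps touches this part of the molecule, and none of them has a readable size, so they give no guide to the direction or size of the change to expect. The expected step from compound 3 to compound 4 in this assay is therefore given only as a rough estimate, an at least 1.6-fold lower number from compound 3 to compound 4 (0.20 log units; that floor lies within the scatter). Compound 4 is expected to give 80000 nM, with an estimated range from 15000 nM to 300000 nM.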

Compound 4, half-maximal inhibitory concentration: 18000 nM
Compound 4: the middle estimate sits 4.4-fold (0.65 log units) above what was measured; measured number inside the range.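

In this assay, within the data shown here, the carbonyl carbon whose other neighbour is an aromatic carbon is the first place where a change gives a readable step: putting 2-(4-bromophenyl)ethenyl in place of methyl there gives an at least 7.1-fold lower number from compound 3 to compound 4 (0.85 log units; beyond the scatter). This shows that the series is not fixed at the assay limit, and that compound 4 is the only one of the compounds shown with a number of its own, while the steps among the other three still cannot be read. The step can be given only as a floor, and its true size stays unknown, because compound 3 has no number of its own: the limit of > 128000 nM in this assay, at which 3 of the 4 values shown sit.

The compounds shown do not tell which part of the entering group goes with the step, since its aromatic ring, its double bond outside that ring and its bromine all enter together. Going by these compounds, it remains open whether a 2-phenylethenyl group without bromine, a saturated 2-(4-bromophenyl)ethyl chain or a 2-(4-aminophenyl)ethenyl group on the same carbonyl carbon would give a step of similar size.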